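A few compounds are considered here, and "the series" means these few. Any claim that something is new, unique, unknown or untested is made for them only; others in the source may bear on it.

Measured so far in a functional assay on HCT-116 cells (Homo sapiens) for cytotoxicity, read by MTT assay, with a stated time of 72 h; a lower number here means a stronger inhibitor, a higher number a weaker inhibitor:

Compound 1, `C[C@@H](Nc1c(C(=O)NCc2ccc(F)cc2)nc(Br)c2cccnc12)c1ccccc1`: in this assay compound 1 is reported only as a limit, > 20000 nM.
Compound 2, `COC(=O)c1nc(Br)c2cccnc2c1N[C@H]1CC[C@H](N)CC1`: for compound 2 this assay gives "not determined" (no result reported).
Compound 3, `C[C@H](NC(=O)c1nc(Br)c2cccnc2c1N[C@H]1CC[C@H](N)CC1)c1ccc(F)cc1`: in this assay compound 3 is reported only as a limit, > 10000 nM.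

Compound 1 therefore stands at the edge of what this assay can see, at the limit of > 20000 nM in this assay, at which 1 of the 3 values shown sits, and not at a number. Going by the values given here, compound 3 sits at a similar edge, (the limit of > 10000 nM in this assay, at which 1 of the 3 values shown sits), and compound 2 has no result at all, so no step between two measured compounds can be sized here, and nothing shows how any change moves the read-out.

Compound 4, `CNc1c(C(=O)NCc2ccc(F)cc2)nc(Br)c2cccnc12`, is compound 1 with one change: methyl in place of 1-phenylethyl on a nitrogen on an aromatic ring. With both measured neighbours of compound 1 at limits, the expectation for compound 4 is that the step that the limit leaves unreadable from compound 1 to compound 4 stays within the scatter of repeats, with no direction to it. Compound 4 is thus estimated at 30000 nM, in a range from 8000 nM to 100000 nM, most likely reported again only as a limit.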

Compound 4, half-maximal inhibitory concentration: > 20000 nM
Compound 4 was reported as a limit; the forecaster's own chance of this, stated with the estimate: 85%; the middle value does not contradict the limit.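

Compound 1 and compound 4 both stand at the same limit of this assay, so the size of the step between them cannot be read: the limit of > 20000 nM in this assay, at which 2 of the 4 values shown sit.

The compounds shown leave open whether any change to the shared core would give a true number in this assay instead of a limit.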